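Removal of the ring chloro on the cinnamoyl side

The source may hold more compounds than are shown below. What is called first, only, known or untested is meant among the compounds shown, and "the series" means these compounds.

Compound 1 `O=C(/C=C/c1ccc(Cl)cc1)Nc1cc(-c2ccc(Br)cc2)[nH]n1` gives 1080 nM in a functional assay on B16-F10 cells (Mus musculus) for antiproliferative activity, read by MTT assay, with a stated time of 48 h (on this read-out higher numbers stand for weaker inhibition and lower numbers for stronger inhibition), the second highest of the three numbers at hand. Compound 3 `Cc1ccc(-c2cc(NC(=O)/C=C/c3ccc(Cl)cc3)n[nH]2)cc1` gives 1520 nM, and the change a 1.4-fold higher number from compound 1 to compound 3 (0.15 log units; within the scatter) stays within the scatter. Compound 2 `O=C(/C=C\c1ccc(C(F)(F)F)cc1)Nc1cc(-c2ccccc2)[nH]n1` gives 640 nM; it differs from compound 1 in more than one place, so only the two values are compared, and they lie within the scatter of one another.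

Compound 4 `O=C(/C=C/c1ccccc1)Nc1cc(-c2ccc(Br)cc2)[nH]n1` is not yet measured. It differs from compound 1 as follows: hydrogen in place of chloro on an aromatic carbon — taken one bond further out, 4-chlorophenyl becomes phenyl. Among the measured compounds shown here, no measured pair in this set changes the cinnamoyl ring alone, so nothing bears directly on the step. For the measured compounds named here, the one single-place step, on the other ring, was within the scatter, and the series so far shows modest spread overall. The expected step of a 1.3-fold higher number from compound 1 to compound 4 (0.11 log units; within the scatter) is therefore small, with at most a slight move toward weaker inhibition. Compound 4 is estimated at 1400 nM, within a range of 600 nM to 3500 nM.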

Compound 4, half-maximal inhibitory concentration: 1270 nM
Beside the measured number, compound 4's estimate is 1.1-fold (0.04 log units) above it; the measured number falls inside the stated range.
By their numbers in this assay, from the lowest: compounds 2, 1, 4 and 3 (each within the scatter of the next, the first and the last beyond it).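

In this assay, among the compounds shown here, this is the first single-place step on the cinnamoyl ring, and hydrogen in place of chloro gives a 1.2-fold higher number from compound 1 to compound 4 (0.07 log units; within the scatter). With the 4-bromophenyl side held constant, the chloro is therefore not required to keep the number in the range of compound 1, and the series now has a step within the scatter on each aryl ring, the other being a 1.4-fold higher number from compound 1 to compound 3 (0.15 log units; within the scatter). No outside evidence bears on this result.

Open, on these data alone, is whether this position stays as flat with a group of another kind, such as an amine, a carboxylic acid or a methoxy, on the same aromatic carbon. Also open, as far as these compounds go, is whether 4-chlorophenyl to phenyl gives a similar step when the other ring carries methyl, as in compound 3.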